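Swapping the aryl ether group on a shared core

The source may report more compounds than this note shows. Statements on the series, on what has been measured and on what is new or still open speak of the compounds shown alone.

compound 1 `NC1=NC2(CCOCC2)N(OCCCOc2ccc(Cl)cc2)C(N)=N1`: "not determined" (no result reported)
compound 2 `Cc1cc(C)cc(OCCCON2C(N)=NC(N)=NC23CCOCC3)c1`: 3570 nM
compound 3 `NC1=NC2(CCSCC2)N(OCCCOc2cc(Cl)c(Cl)cc2Cl)C(N)=N1`: 110 nM

In a functional assay on MDA-MB-231 cells (Homo sapiens) for antiproliferative activity, read by MTT assay, with a stated time of 72 h (on this read-out higher numbers stand for weaker inhibition and lower numbers for stronger inhibition), compound 1 has no place on the scale, since its entry reads "not determined" (no result reported). It therefore offers no number to start from. Compounds 2 and 3 differ from each other in more than one place, so they do not isolate the effect of any single change.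

The next compound is compound 4 `NC1=NC2(CCOCC2)N(OCCCOc2ccccc2Br)C(N)=N1`. It puts 2-bromophenyl in place of 4-chlorophenyl on an oxygen on a saturated carbon. No measured step sizes this swap, and with no value for compound 1, no direction can be favoured. The best guide is compound 2, at 3570 nM, which has the same core as the new compound. Compound 3, with a different core and a more heavily chlorinated ring, gives 110 nM, and this pulls the expectation only slightly downward.

For compound 4 the expected value is 1800 nM, with an estimated range of 400 nM to 7000 nM.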

Compound 4, half-maximal inhibitory concentration: 910 nM
Compound 4: the middle estimate sits 2.0-fold (0.30 log units) above what was measured; the measured number falls inside the stated range.
By their numbers in this assay, from the lowest: compound 3; then compound 4; then compound 2.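

With the shared core held fixed, a change on the oxygen on a saturated carbon now has a size in this assay: 2-bromophenyl in place of 3,5-dimethylphenyl gives a 3.9-fold lower number from compound 2 to compound 4 (0.59 log units; beyond the scatter) and this modest step lies beyond the usual scatter. For the compounds shown here, it is the only comparison here in which the compounds differ in one place, so it shows that this position responds to the aryl group alone, with no change in the core. Nothing measured here bears on why the number moves.

The step from compound 1 to compound 4 cannot be read, as compound 1 has no number on this scale. Also open, from the compounds shown here alone, is whether the bromine itself or the loss of the two methyl groups matters more, and how an amine on the ring or a longer chain would behave.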